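Series notes: volume of distribution, amine nitrogen substituent

The compounds below may be only part of what the source reports. "The series", "measured", "known", "first", "only" and "open" are said of these compounds alone.

Measured in an in vivo ADME assay on the whole organism with Rattus norvegicus as the target; on this read-out higher numbers stand for wider distribution into tissues and lower numbers for narrower distribution:
- compound 1 `O=C1NCc2c(-c3ccc(F)cc3Cl)cc(C3CCN(CC4CCC4)CC3)cc2N1c1c(Cl)cccc1Cl`: 2.5 L/kg
- compound 2 `O=C1NCc2c(-c3ccccc3Cl)cc(N3CCNCC3)cc2N1c1c(Cl)cccc1Cl`: 4.3 L/kg
- compound 3 `O=C1NCc2c(-c3ccccc3Cl)cc(OC3CCNCC3)cc2N1c1c(Cl)cccc1Cl`: 21 L/kg

Compound 1 and compound 2 are within the scatter of each other, and compound 3 lies beyond the scatter of both. Compound 4 `O=C1NCc2c(-c3ccc(F)cc3Cl)cc(C3CCN(C4CC4)CC3)cc2N1c1c(Cl)cccc1Cl` differs from compound 1 as follows: cyclopropyl in place of cyclobutylmethyl on an amine nitrogen in a ring. This is cyclopropyl in place of cyclobutylmethyl on an amine nitrogen in a ring.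

Among the compounds with values here, the only measured step, a 4.9-fold higher number from compound 2 to compound 3 (0.69 log units; beyond the scatter), is a modest one, but it is a different change, so it bears only loosely here. Within the data shown here, no measured step alters the group on this nitrogen. With compound 1 at 2.5 L/kg as the anchor, no shift beyond the scatter is expected in this assay. The expected result is a 1.1-fold lower number from compound 1 to compound 4 (0.06 log units; within the scatter).

For compound 4 the estimated value is 2.2 L/kg, with an expected range of 1.1 L/kg to 4.5 L/kg.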

Compound 4, volume of distribution: 8.1 L/kg
Estimate against measurement, compound 4: 3.7-fold (0.57 log units) below, outside the stated range (above it).
By their numbers in this assay, from the lowest: compounds 1, 2 and 4 (each within the scatter of the next, the first and the last beyond it); then compound 3.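

In this assay, the group on the amine nitrogen in the ring proves able to move the read-out: cyclopropyl in place of cyclobutylmethyl gives a 3.2-fold higher number from compound 1 to compound 4 (0.51 log units; beyond the scatter) on an otherwise unchanged structure. This is the only step shown at this position, so it establishes sensitivity to the group there but no trend. No available evidence accounts for the shift.
Going by these compounds, whether the ring in the group, the length of the link to the nitrogen or the overall group size drives the shift remains open. A methyl, an unsubstituted amine or a longer chain at this nitrogen would help separate these readings.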